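Amide aryl swaps on the shared core

A few compounds are considered here, and "the series" means these few. Any claim that something is new, unique, unknown or untested is made for them only; others in the source may bear on it.

Going by the values given here, compound 3 `CN1[C@@H]2c3[nH]c4ccccc4c3C[C@H]1[C@H](C#N)N1[C@@H](CNC(=O)c3ccc4ccccc4c3)c3[nH]c4ccccc4c3C[C@@H]21` gives 1110 nM in a functional assay on BGC-823 cells (Homo sapiens) for cytotoxicity, read by MTT assay, with a stated time of 72 h (on this read-out lower numbers stand for stronger inhibition and higher numbers for weaker inhibition), the highest of the three numbers so far. Compound 1 `CN1[C@@H]2c3[nH]c4ccccc4c3C[C@H]1[C@H](C#N)N1[C@@H](CNC(=O)c3ccc(Cl)cc3)c3[nH]c4ccccc4c3C[C@@H]21` gives 110 nM, and compound 2 `CCc1ccc(C(=O)NC[C@H]2c3[nH]c4ccccc4c3C[C@H]3[C@H]4c5[nH]c6ccccc6c5C[C@@H]([C@H](C#N)N23)N4C)cc1` gives 660 nM. The steps of a 10-fold higher number from compound 1 to compound 3 (1.00 log units; beyond the scatter) and a 1.7-fold higher number from compound 2 to compound 3 (0.23 log units; within the scatter) concern the same carbonyl position, as does a 6.0-fold higher number from compound 1 to compound 2 (0.78 log units; beyond the scatter). Compound 4 `CN1[C@@H]2c3[nH]c4ccccc4c3C[C@H]1[C@H](C#N)N1[C@@H](CNC(=O)c3cc4ccccc4s3)c3[nH]c4ccccc4c3C[C@@H]21` differs from compound 3 by 1-benzothiophen-2-yl in place of naphthalen-2-yl on a carbonyl carbon. Among the compounds with values here, no measured step trades one fused bicyclic aryl for another at the carbonyl carbon, so the only guide is that the entering group is close in size to the leaving one. The step of a 1.2-fold lower number from compound 3 to compound 4 (0.09 log units; within the scatter) is therefore expected to stay within the scatter in this assay. Compound 4 is estimated at 900 nM, with a range of 350 nM to 2500 nM.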

Compound 4, half-maximal inhibitory concentration: 240 nM
Estimate against measurement, compound 4: 3.8-fold (0.57 log units) above; the measured number lies below the stated range.
By their numbers in this assay, from the lowest: compound 1; then compound 4; then compounds 2 and 3 (each within the scatter of the next).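

In this assay, the two fused bicyclic aryl groups on the carbonyl carbon are not interchangeable: a 4.6-fold lower number from compound 3 to compound 4 (0.67 log units; beyond the scatter) lies beyond the scatter, so closeness in size between 1-benzothiophen-2-yl and naphthalen-2-yl does not fix the number here. The bicyclic group entering here also separates from the monocyclic ones, with a 2.8-fold lower number from compound 2 to compound 4 (0.44 log units; beyond the scatter) against 4-ethylphenyl and a 2.2-fold higher number from compound 1 to compound 4 (0.34 log units; beyond the scatter) against 4-chlorophenyl, so 4-chlorophenyl keeps the lowest number. Nothing measured here accounts for the gap between the two bicyclic groups.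

As far as these compounds go, whether the ring sulfur matters stays open. A 1-benzofuran-2-yl group on the same carbonyl carbon, with oxygen in place of sulfur, would bear on that.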